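The source may report more compounds than this note shows. Statements on the series, on what has been measured and on what is new or still open speak of the compounds shown alone.

Measured so far:
- Compound 1, `CCCCCCCCc1ccc(OCC(=O)Cn2nnc(-c3cccc(Cl)c3)n2)cc1`: 69%
- Compound 2, `CCCCCCCCc1ccc(OCC(=O)Cn2nnc(-c3ccc(S(=O)(=O)N(C)C)cc3)n2)cc1`: 65%

In an ADME assay on S9 fraction from liver (Rattus norvegicus) for metabolic stability, read by LC-MS, using NADPH, with a stated time of 30 min (a higher number here means that more of the compound is left, a lower number that less of the compound is left), compound 1 gives 69%, and compound 2 gives 65%. Within the data shown here, of the two numbers, compound 2 holds the lowest, but the only step between them, a number 4 percentage points lower from compound 1 to compound 2 (within the scatter), lies within the scatter, so the two cannot really be told apart.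

Compound 3, `CCCCCCCCc1ccc(OCC(=O)Cn2nnc(-c3cccc(C(=O)O)c3)n2)cc1`, has not yet been measured. It differs from compound 2 in one place: 3-carboxyphenyl in place of 4-(dimethylsulfamoyl)phenyl on an aromatic carbon.

Among the measured compounds shown here, the only measured step that bears on this change is the one that also swapped the aryl group on the shared core, a number 4 percentage points lower from compound 1 to compound 2 (within the scatter), and it stayed within the scatter. With nothing else to go on, no step beyond the scatter is expected in this assay. Compound 3 is therefore estimated at 65%, within a range of 45% to 85%. The expected step from compound 2 is no change at the digits printed from compound 2 to compound 3 (within the scatter).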

Compound 3, percent of the compound remaining: < 5%
Compound 3: no number, only a limit (the forecaster's own chance of this, stated with the estimate: 2%); middle value at least 60 percentage points away from the limit.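

Among these compounds, the place on the shared core that bears the aryl group is not as forgiving as the earlier pair suggested, since the only earlier change there stayed within the scatter. Here the change gives a number at least 60 percentage points lower from compound 2 to compound 3 (beyond the scatter), and the smaller exchange of one group on the same aryl ring gives a number at least 64 percentage points lower from compound 1 to compound 3 (beyond the scatter), so carboxy in place of chloro is enough on its own to produce a large step. In this assay compound 3 gives < 5%, which is a limit and not a number, so both steps are minimum sizes: the limit of < 5% in this assay, at which 1 of the 3 values shown sits.

The compounds shown do not tell why so little of compound 3 is left. From the compounds shown here alone, whether a methyl ester or a primary amide in place of the carboxy group would behave like 3-chlorophenyl or like 3-carboxyphenyl remains open.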